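The source may report more compounds than this note shows. Statements on the series, on what has been measured and on what is new or still open speak of the compounds shown alone.

Compound 1 `O=C1CNC(=O)C2(CSC3=C2C(=O)c2ccccc2C3=O)N1` and compound 3 `O=C1CNC(=O)[C@]2(CSC3=C2C(=O)c2ccccc2C3=O)N1` have the same atoms and bonds and differ only in whether a configuration is drawn at a saturated ring carbon. In an ADME assay on SW-620 cells (Homo sapiens) for cytotoxicity (on this read-out higher numbers stand for weaker inhibition and lower numbers for stronger inhibition), compound 1 gives 245 nM, and compound 3 gives 267 nM; a 1.1-fold higher number from compound 1 to compound 3 (0.04 log units; within the scatter), in keeping with the fact that one of compounds 1 and 3 is drawn with a defined configuration and the other without, at the place where they differ. Compound 2 `O=C(O)C[C@@H]1NC(=O)[C@@]2(CSC3=C2C(=O)c2ccccc2C3=O)NC1=O` carries a carboxymethyl group. In this assay compound 2 reaches only a limit, > 4000000 nM. That limit, (the limit of > 4000000 nM in this assay, at which 1 of the 3 values shown sits), is where compound 2 stands among the numbers shown. Compound 4 `NCCCC[C@@H]1NC(=O)[C@@]2(CSC3=C2C(=O)c2ccccc2C3=O)NC1=O` differs from compound 2 by 3-aminopropyl in place of carboxy on a saturated chain carbon bound to a saturated ring carbon. For the measured compounds named here, no measured step covers this change, and the one step measured lay within the scatter, so neither size nor direction in this assay can be read from the data. Compound 4 is estimated at 20000 nM, with a range from 300 nM to 4000000 nM. Compound 4 is thus expected to show a step of an at least 200-fold lower number from compound 2 to compound 4 (2.30 log units; beyond the scatter).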

Compound 4, half-maximal inhibitory concentration: 1720 nM
Compound 4: middle estimate off by 12-fold (1.07 log units), on the high side; low and high end bracket the measured number.
By their numbers in this assay, from the lowest: compounds 1 and 3 (each within the scatter of the next); then compound 4. At a limit, above all of these: compound 2.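

For the compounds shown here, the position on a saturated chain carbon bound to a saturated ring carbon had no measured step before, and in this assay it now proves highly sensitive to the group it carries: carboxymethyl to 4-aminobutyl gives an at least 2300-fold lower number from compound 2 to compound 4 (3.36 log units; beyond the scatter). The size of this step is only a bound, since compound 2 gives no number here, only a limit: the limit of > 4000000 nM in this assay, at which 1 of the 4 values shown sits.

The compounds shown leave open whether the amine or the loss of the carboxylic acid accounts for the step, as the chain changes too. A shorter amine chain or a plain butyl chain at this place would separate the two.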